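A few compounds are considered here, and "the series" means these few. Any claim that something is new, unique, unknown or untested is made for them only; others in the source may bear on it.

Going by the values given here, in a functional assay on CCRF-CEM cells (Homo sapiens) for inhibition, read by sulforhodamine B assay, with a stated time of 48 h, tested at 10 uM (a lower number here means less inhibition, a higher number more inhibition at the concentration tested (going by the name of the read-out)), compound 3 `CC(=O)c1ccc(-c2cn3ccnc3c(-c3ccc4ncn(C5CCCCC5)c4c3)n2)cc1` gives 1.1%, the lowest of the three numbers so far. Compound 1 `Brc1cn2ccnc2c(-c2ccc3ncn(C4CCCCC4)c3c2)n1` gives 7.68%, and compound 2 `COc1ccc(-c2cn3ccnc3c(-c3ccc4ncn(C5CCCCC5)c4c3)n2)cc1` gives 93.3%. The step of a number 6.6 percentage points lower from compound 1 to compound 3 (within the scatter) lies within the scatter, whereas a number 85.6 percentage points higher from compound 1 to compound 2 (beyond the scatter) and a number 92.2 percentage points lower from compound 2 to compound 3 (beyond the scatter) are both large. Compound 4 `Fc1ccccc1-c1cn2ccnc2c(-c2ccc3ncn(C4CCCCC4)c3c2)n1` differs from compound 3 by 2-fluorophenyl in place of 4-acetylphenyl on an aromatic carbon. The two large steps bear on this change, as each alters the group on the same aromatic carbon; together they show that a change in this part of the structure can move the read-out across most of its range, in either direction. A sizeable rise is therefore expected, a number 38.9 percentage points higher from compound 3 to compound 4 (beyond the scatter), though with little certainty. Compound 4 is estimated at 40%, within 5% to 85%.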

Compound 4, a percentage reported as inhibition, at one concentration (the size of the read-out at that concentration, not a potency): 22.5%
Compound 4: middle estimate off by 17.5 percentage points, on the high side; measured number inside the range.
By their numbers in this assay, from the lowest: compounds 3 and 1 (each within the scatter of the next); then compound 4; then compound 2.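

In this assay, 2-fluorophenyl gives an intermediate result at this aromatic carbon: a number 21.4 percentage points higher from compound 3 to compound 4 (beyond the scatter) and a number 14.8 percentage points higher from compound 1 to compound 4 (beyond the scatter) are modest, whereas a number 70.8 percentage points lower from compound 2 to compound 4 (beyond the scatter) is large. Of the three phenyl groups compared here, only 4-methoxyphenyl reaches the high level, so carrying a phenyl ring at this carbon is not sufficient for it.

No available evidence accounts for these differences. As far as these compounds go, it remains open how far the result depends on the identity and ring position of the substituent, and how a phenyl ring bearing an amine or a carboxylic acid would read.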